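Adding a bromo group to a phenyl ring

The source may hold more compounds than are shown below. What is called first, only, known or untested is meant among the compounds shown, and "the series" means these compounds.

Compound 1 `O=C1/C(=C/c2ccccc2)COC/C1=C\c1ccccc1F` gives 17600 nM
Compound 2 `COc1cc(/C=C2\COC/C(=C\c3ccccc3F)C2=O)ccc1O` gives 21400 nM
Compound 3 `COc1ccc(OC)c(/C=C2\COC/C(=C\c3ccccc3F)C2=O)c1` gives 8700 nM

These values come from a functional assay on A549 cells (Homo sapiens) for cytotoxicity, read by MTT assay, with a stated time of 72 h; a lower number here means a stronger inhibitor, a higher number a weaker inhibitor. Compound 1 and compound 2 lie within the usual scatter of each other, while compound 3 has a lower number than compound 1, beyond the scatter. Compound 4 `O=C1/C(=C/c2ccccc2F)COC/C1=C\c1ccccc1Br` turns the phenyl of compound 1 into 2-bromophenyl, with bromo in place of hydrogen on an aromatic carbon, ortho to a large group (bromo in place of hydrogen on an aromatic carbon). For the measured compounds named here, no measured pair shows this change directly. Compound 3, at 8700 nM, sets the widest gap from compound 1 in this small set, so only a modest shift toward lower numbers is expected. The expected step of a 1.4-fold lower number from compound 1 to compound 4 (0.13 log units; within the scatter) stays within the scatter. For compound 4 the estimated value is 13000 nM, with an expected range of 5500 nM to 30000 nM.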

Compound 4, half-maximal inhibitory concentration: 6500 nM
Compound 4: the middle estimate sits 2.0-fold (0.30 log units) above what was measured; the measured number falls inside the stated range.
By their numbers in this assay, from the lowest: compounds 4 and 3 (each within the scatter of the next); then compounds 1 and 2 (each within the scatter of the next).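

In this assay the change from phenyl to 2-bromophenyl, with bromo ortho to a large group, gives a 2.7-fold lower number from compound 1 to compound 4 (0.43 log units; beyond the scatter) and so forms a modest step beyond the usual scatter. For the compounds shown here, this is the first pair in the set that differs in one place only, so this shift can be tied to that single swap of hydrogen for bromo. Nothing measured here explains why the number moves. On these data alone, whether chloro or an amine in place of bromo would give a step of similar size stays open. So does whether bromo would give the same step on the substituted rings of compound 2 and compound 3.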